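Adding a Second Chloro to the Strongest Compound

The source may report more compounds than this note shows. Statements on the series, on what has been measured and on what is new or still open speak of the compounds shown alone.

Measured so far in a functional assay on lung (Cavia porcellus) for binding affinity to cysteinyl leukotriene receptor (Homo sapiens); a lower number here means a stronger inhibitor, a higher number a weaker inhibitor:
compound 1 `O=C(O)CCCOc1cccc(/C=C/c2ccc3cc(Cl)ccc3n2)c1` gives 270 nM
compound 2 `O=C(O)CCCOc1cccc(/C=C/c2ccc3ccc(Cl)cc3n2)c1` gives 39 nM
compound 3 `O=C(O)CCCOc1cccc(/C=C/c2ccc3ccccc3n2)c1` gives 480 nM

Compound 2 gives the lowest number of the three, and its distance to each of the others lies beyond the scatter, so it is the strongest inhibitor among the measured compounds. Compound 3 carries no chloro at all, while compound 1 and compound 2 each carry one chloro, at different places on the shared core.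

Compound 4 `O=C(O)CCCOc1cccc(/C=C/c2ccc3cc(Cl)c(Cl)cc3n2)c1` has not yet been measured. It differs from compound 2 by chloro in place of hydrogen on an aromatic carbon, so it carries both chloro groups at once. Among the compounds with values here, two measured steps bear on this change. Taking away the chloro of compound 2 gave a 12-fold higher number from compound 2 to compound 3 (1.09 log units; beyond the scatter). Taking away the chloro of compound 1, which sits where the new chloro of compound 4 enters, gave a 1.8-fold higher number from compound 1 to compound 3 (0.25 log units; within the scatter). Within the data shown here, the second step is the one that matches the change here, and it was small, so adding that chloro to compound 2 is expected to alter the number little, if at all. Compound 4 is therefore expected to give 30 nM, in a range from 12 nM to 90 nM, with the expected 1.3-fold lower number from compound 2 to compound 4 (0.11 log units; within the scatter) staying within the scatter.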

Compound 4, half-maximal inhibitory concentration: 54 nM
Compound 4: the middle estimate sits 1.8-fold (0.26 log units) below what was measured; low and high end bracket the measured number.
By their numbers in this assay, from the lowest: compounds 2 and 4 (each within the scatter of the next); then compounds 1 and 3 (each within the scatter of the next).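

In this assay, placing a chloro ortho to a chloro group gives a 1.4-fold higher number from compound 2 to compound 4 (0.14 log units; within the scatter), so this position stays as quiet on a core that already carries a chloro as it was on the core with none: the same change on two cores in this assay, a 1.8-fold higher number (0.25 log units; within the scatter) from compound 1 to compound 3 and a 1.4-fold lower number (0.14 log units; within the scatter) from compound 4 to compound 2, 2.5-fold (0.39 log units) apart, within the scatter of two such steps

The other chloro, the one that sets compound 2 apart, keeps its lowering of the number with the new chloro present, giving a 5.0-fold lower number from compound 1 to compound 4 (0.70 log units; beyond the scatter), a step comparable to the one it gives without that chloro: the same change on two cores in this assay, a 12-fold higher number (1.09 log units; beyond the scatter) from compound 2 to compound 3 and a 5.0-fold higher number (0.70 log units; beyond the scatter) from compound 4 to compound 1, 2.5-fold (0.39 log units) apart, within the scatter of two such steps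

Only with compound 4 do the compounds form a complete square, and within it neither chloro visibly alters the step of the other.

As far as these compounds go, whether this position accepts anything other than chloro remains open, for example an amine or a methoxy group. Also open, from the compounds shown here alone, is how a longer chain carrying the carboxylic acid would change the number.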